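Adding a methyl to the ring of compound 2

A few compounds are considered here, and "the series" means these few. Any claim that something is new, unique, unknown or untested is made for them only; others in the source may bear on it.

Of the compounds shown here, two of a shared core have been measured in a functional assay on A549 cells (Homo sapiens) for cytotoxicity, read by sulforhodamine B assay; a lower number here means a stronger inhibitor, a higher number a weaker inhibitor. Compound 1 `Cc1ccc2c(=O)n(C)c3c(c2c1)CCOc1ccccc1-3` gives 61300 nM in this assay. Compound 2 `COc1ccc(Cn2c3c(c4ccccc4c2=O)CCOc2ccccc2-3)cc1` gives 11000 nM in this assay, the lower of the two numbers, and its nearest neighbour is compound 1 with a number that is higher by a margin beyond the usual scatter. Compound 3 `COc1ccc(Cn2c3c(c4cc(C)ccc4c2=O)CCOc2ccccc2-3)cc1` has not yet been measured in this assay. It differs from compound 2 in one place: methyl in place of hydrogen on an aromatic carbon. For the measured compounds named here, no pair of measured compounds shows this change on its own, so its size cannot be read from a measured step. Compound 1 carries the same methyl at that position but differs in other places as well; the value of compound 1, 61300 nM, therefore says nothing clean about the methyl alone. The step is therefore expected to be small, in either direction or none beyond the scatter. The expected step of a 1.1-fold higher number from compound 2 to compound 3 (0.04 log units; within the scatter) reflects that. For compound 3 the estimate in this assay is 12000 nM, with a range from 4000 nM to 36000 nM.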

Compound 3, half-maximal inhibitory concentration: > 100000 nM
Compound 3: only a limit was reported; the forecaster's own chance of this, stated with the estimate: 5%; middle value at least 8.3-fold (0.92 log units) away from the limit.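

In this assay, this position is not indifferent to a small change: methyl in place of hydrogen on this aromatic carbon, meta to a fused ring and para to a fused ring, gives an at least 9.0-fold higher number from compound 2 to compound 3 (0.95 log units; beyond the scatter). For the compounds shown here, this is the first measured view of the methyl on its own, and a single added carbon is enough to move the number beyond the scatter, towards weaker inhibition. The second pair, which differs in 4-methoxyphenyl in place of hydrogen on a saturated chain carbon bound to an aromatic nitrogen, gives an at least 1.6-fold higher number from compound 1 to compound 3 (0.21 log units; that floor lies within the scatter), so with the methyl in place that floor does not separate the two compounds beyond the scatter. Compound 3 is reported only as a limit, so neither step has a known full size: the limit of > 100000 nM in this assay, at which 1 of the 3 values shown sits.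

As far as these compounds go, it remains open whether the loss belongs to the methyl alone or whether a fluorine, a methoxy or an amine on the same carbon would do the same. Also open, from the compounds shown here alone, is whether a longer chain or a benzyl without the methoxy on the aromatic nitrogen would change how this position responds.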